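A few compounds are considered here, and "the series" means these few. Any claim that something is new, unique, unknown or untested is made for them only; others in the source may bear on it.

Compound 1 `Cc1c(C(=O)N/N=C\c2c(O)cccc2F)oc2cccc(O)c12` gives 2200 nM in a functional assay on HT-29 cells (Homo sapiens) for inhibition; on this read-out higher numbers stand for weaker inhibition and lower numbers for stronger inhibition.
Compound 2 `Cc1c(C(=O)N/N=C\c2ccc(O)cc2O)oc2cccc(O)c12` gives 2880 nM in this assay.

Of these two numbers compound 2 stands highest, with compound 1 as its nearest neighbour at a distance within the scatter. Compound 3 `Cc1c(C(=O)N/N=C\c2ccc(O)c(O)c2O)oc2cccc(O)c12` differs from compound 2 by hydroxy in place of hydrogen on an aromatic carbon, ortho to two hydroxy groups. For the measured compounds named here, the only measured step, a 1.3-fold higher number from compound 1 to compound 2 (0.12 log units; within the scatter), also exchanged the substituents on this same ring and stayed within the scatter, so no step beyond the scatter is expected in this assay for compound 3. Compound 3 is therefore estimated at 2800 nM, between 1200 nM and 7000 nM, an expected step of a 1.0-fold lower number from compound 2 to compound 3 (0.01 log units; within the scatter).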

Compound 3, half-maximal inhibitory concentration: > 20000 nM
Compound 3 ended at the assay's limit; the forecaster's own chance of this, stated with the estimate: 5%; at least 7.1-fold (0.85 log units) between middle value and limit.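

Placing one hydroxy group on this aromatic carbon, ortho to two hydroxy groups, produces an at least 6.9-fold higher number from compound 2 to compound 3 (0.84 log units; beyond the scatter) in this assay, the first step beyond the scatter and one toward weaker inhibition. The earlier exchange of substituents on the same ring, a 1.3-fold higher number from compound 1 to compound 2 (0.12 log units; within the scatter), showed no such sensitivity. The value of compound 3 is a limit of the assay and not a number, so the full size of the step stays unknown: the limit of > 20000 nM in this assay, at which 1 of the 3 values shown sits.

The compounds shown leave open whether this outcome is specific to hydroxy at this carbon. A methoxy group or an amine at the same place would separate the two readings.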